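The source may hold more compounds than are shown below. What is called first, only, known or untested is meant among the compounds shown, and "the series" means these compounds.

Measured in a functional assay on MCF7 cells (Homo sapiens) for antiproliferative activity, read by MTT assay, with a stated time of 48 h; on this read-out lower numbers stand for stronger inhibition and higher numbers for weaker inhibition:
compound 1 `Fc1ccc2[nH]c(-c3cn(-c4ccccc4)nc3-c3ccccc3)nc2c1`: 2430 nM
compound 2 `Brc1ccc2[nH]c(-c3cn(-c4ccccc4)nc3-c3ccccc3)nc2c1`: 830 nM
compound 3 `Fc1ccc(-c2nn(-c3ccccc3)cc2-c2nc3cc(F)ccc3[nH]2)cc1`: 950 nM

The values of compound 3 and compound 2 lie within the scatter of each other, and both numbers are lower than that of compound 1. For compound 3 the gain is a 2.6-fold lower number from compound 1 to compound 3 (0.41 log units; beyond the scatter), a modest step beyond the scatter.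

The next compound, compound 4 `Cc1ccc2[nH]c(-c3cn(-c4ccccc4)nc3-c3ccc(F)cc3)nc2c1`, differs from compound 3 in one place: methyl in place of fluoro on an aromatic carbon. In words, this is methyl in place of fluoro on an aromatic carbon.

Among the measured compounds shown here, no measured step brings in a methyl group, so the evidence is indirect. For the measured compounds named here, the closest precedent also replaces that fluoro group: bromo in place of fluoro gave a 2.9-fold lower number from compound 1 to compound 2 (0.47 log units; beyond the scatter), again modest. The other measured step, a 2.6-fold lower number from compound 1 to compound 3 (0.41 log units; beyond the scatter), bears only on the fluoro group that compound 4 keeps from compound 3, so it says little about the new change.

On this basis, no step beyond the scatter is expected in this assay, with only a slight lean towards a lower number. The expected step is a 1.3-fold lower number from compound 3 to compound 4 (0.10 log units; within the scatter). The estimated value for compound 4 is 750 nM, with an expected range of 280 nM to 2000 nM.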

Compound 4, half-maximal inhibitory concentration: 1120 nM
Estimate against measurement, compound 4: 1.5-fold (0.17 log units) below, within the range that was stated.
By their numbers in this assay, from the lowest: compounds 2, 3 and 4 (each within the scatter of the next); then compound 1.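

In this assay, methyl in place of fluoro on this aromatic carbon gives a 1.2-fold higher number from compound 3 to compound 4 (0.07 log units; within the scatter), so with the second fluoro group held in place, the two groups cannot be told apart at this position. Among the compounds shown here, until now the only change measured here was bromo in place of fluoro, a 2.9-fold lower number from compound 1 to compound 2 (0.47 log units; beyond the scatter), and that step lies beyond the scatter, so this position is not indifferent to every group; the pair of compound 3 and compound 4 adds that a swap of one heavy atom for another, fluorine for carbon, can leave the number unchanged within the scatter. Nothing measured alongside these numbers gives a reason for the result.

As far as these compounds go, what remains open is whether methyl would match fluoro equally closely on the core of compound 1, without the fluoro group that compound 3 and compound 4 share, since the bromo step was read on that simpler background. From the compounds shown here alone, it is also open how this position would respond to a group larger than a single heavy atom or of a different kind, such as a methoxy group, an amine or a carboxylic acid.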